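A few compounds are considered here, and "the series" means these few. Any claim that something is new, unique, unknown or untested is made for them only; others in the source may bear on it.

Compound 1 `CCOCc1c(C)coc1-c1ccc2c(c1OC)CCCC2(C)C`: 21.6 uM
Compound 2 `COC(=O)c1c(C)coc1-c1ccc2c(c1OC)CCCC2(C)C`: 53.4 uM
Compound 3 `COc1c(-c2occ(C)c2C(=O)O)ccc2c1CCCC2(C)C`: 43.3 uM

All three were tested in a functional assay on KB cells (Homo sapiens) for cytotoxicity, read by sulforhodamine B assay, with a stated time of 3 days; on this read-out lower numbers stand for an effect already at smaller amounts and higher numbers for an effect only at larger amounts of compound. Compound 3 lies within the scatter of both other compounds, as shown by a 1.2-fold lower number from compound 2 to compound 3 (0.09 log units; within the scatter) and by a 2.0-fold higher number from compound 1 to compound 3 (0.30 log units; within the scatter). Compound 4 `COc1c(-c2occ(C)c2COC(C)=O)ccc2c1CCCC2(C)C` carries acetoxymethyl in place of carboxy on an aromatic carbon. Within the data shown here, no measured compound carries acetoxymethyl, so the nearest guide is the ethoxymethyl group of compound 1 at 21.6 uM. Changes at this carbon have so far been small, the largest being modest: a 2.5-fold higher number from compound 1 to compound 2 (0.39 log units; beyond the scatter). A slight shift towards compound 1 is therefore expected, staying within the scatter: a 1.4-fold lower number from compound 3 to compound 4 (0.16 log units; within the scatter). Compound 4 is estimated at 30 uM, with an expected range of 13 uM to 65 uM.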

Compound 4, concentration for half-maximal effect: 25.4 uM
Estimate against measurement, compound 4: 1.2-fold (0.07 log units) above, within the range that was stated.
By their numbers in this assay, from the lowest: compounds 1, 4, 3 and 2 (each within the scatter of the next, the first and the last beyond it).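

In this assay, acetoxymethyl on this aromatic carbon stays within the scatter of carboxy (a 1.7-fold lower number from compound 3 to compound 4 (0.23 log units; within the scatter)) and of ethoxymethyl (a 1.2-fold higher number from compound 1 to compound 4 (0.07 log units; within the scatter)). It stands modestly apart from methoxycarbonyl, however (a 2.1-fold lower number from compound 2 to compound 4 (0.32 log units; beyond the scatter)), so two ester groups at this carbon need not give the same number. No measurement shown gives a reason for this.

As far as these compounds go, whether an amine or an amide at this carbon would stay in the same narrow span remains open. So does the outcome of a longer chain here.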